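The source may hold more compounds than are shown below. What is called first, only, known or untested is meant among the compounds shown, and "the series" means these compounds.

Measured in an ADME assay on microsomes from liver (Homo sapiens) for metabolic stability, read by LC-MS, with a stated time of 30 min, tested at 1 uM; on this read-out lower numbers stand for slow clearance and higher numbers for fast clearance:

- compound 1 `Fc1ccc(-c2ccc3nnc(Cc4ccc5ncccc5c4)n3n2)cc1F`: 13.4 mL.min-1.g-1
- compound 2 `C[C@@H](c1ccc2ncccc2c1)c1nnc2ccc(-c3cccc(C#N)c3)nn12`: 17.9 mL.min-1.g-1

Compound 1 stands level with compound 2, as the two numbers lie within the usual scatter of repeated measurements. Neither can be called the more stable on this evidence.

Compound 3 `Nc1ccc2nnc(Cc3ccc4ncccc4c3)n2n1` has not yet been measured. It differs from compound 1 in one place, with amino in place of 3,4-difluorophenyl on an aromatic carbon of a six-membered aromatic ring with 2 nitrogen (amino in place of 3,4-difluorophenyl on an aromatic carbon).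

Within the data shown here, no two measured compounds differ in just one place, so the data show nothing directly about such a swap. Compound 1, at 13.4 mL.min-1.g-1, and compound 2, at 17.9 mL.min-1.g-1, both keep a phenyl ring on the core, whereas compound 3 has none. This is thin support, resting on a judgement and not on a measured trend. Even so, slower clearance is the expected direction in this assay, by a margin just beyond the scatter. The estimated change is a 2.2-fold lower number from compound 1 to compound 3 (0.35 log units; beyond the scatter). For compound 3 the expected value is 6 mL.min-1.g-1, with an estimated range from 2 mL.min-1.g-1 to 15 mL.min-1.g-1.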

Compound 3, intrinsic clearance in microsomes: < 7.6 mL.min-1.g-1
Compound 3 was reported as a limit (the forecaster's own chance of this, stated with the estimate: 15%); the middle value does not contradict the limit.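

In this assay, compounds 1 and 3 form the first pair shown that differs in only one place, which gives a direct look at this position on the six-membered aromatic ring with 2 nitrogen: amino in place of 3,4-difluorophenyl gives an at least 1.7-fold lower number from compound 1 to compound 3 (0.24 log units; that floor lies within the scatter). The reading for compound 3 is a limit and not a number: the limit of < 7.6 mL.min-1.g-1 in this assay, at which 1 of the 3 values shown sits. The pair therefore shows that the ring of the 3,4-difluorophenyl group can give way to amino at this position without the clearance number going up, but the floor of the step does not establish a real fall in clearance.

The pair leaves open whether the outcome goes with losing the 3,4-difluorophenyl group or with gaining the amino, as the swap does both at once. Going by these compounds, a methoxy group or a dimethylamino group on the same aromatic carbon would help to separate the two, and it also remains open whether the same swap would give a similar step on the core of compound 2, which carries a nitrile-bearing phenyl ring.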